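Cyclohexylamino replacing benzyl(methyl)amino on two related cores

This account rests on a few compounds, and the source may have more. Where it says the series, first, only, none or still open, it means among the compounds named here.

Measured so far:
compound 1, `O=c1nc(NC2CCCCC2)oc2c([N+](=O)[O-])cc(C(F)(F)F)cc12`, 5.39 ug/mL
compound 2, `CN(Cc1ccccc1)c1nc(=O)c2cc(C(F)(F)F)cc([N+](=O)[O-])c2o1`, 3.84 ug/mL
compound 3, `CN(Cc1ccccc1)c1cc(=O)c2cc(C(F)(F)F)cc([N+](=O)[O-])c2s1`, > 64 ug/mL

In an ADME assay on Vero cells (Chlorocebus sabaeus) for cytotoxicity, read by MTT assay, with a stated time of 48 h (a lower number here means a stronger inhibitor, a higher number a weaker inhibitor), compound 2 gives 3.84 ug/mL. Compound 1 shares its core with compound 2 and differs from it by a single change, (cyclohexylamino in place of benzyl(methyl)amino on an aromatic carbon). This change produced a 1.4-fold higher number from compound 2 to compound 1 (0.15 log units; within the scatter), so the two compounds are indistinguishable in this assay.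

For compound 3 the assay reports only a limit, > 64 ug/mL, and not a number. Compound 3 stands on a different core from compound 2; how the two cores differ is not broken down here.

Compound 4, `O=c1cc(NC2CCCCC2)sc2c([N+](=O)[O-])cc(C(F)(F)F)cc12`, is not yet measured. It is related to compound 3 by the same kind of change that leads from compound 2 to compound 1, namely (cyclohexylamino in place of benzyl(methyl)amino on an aromatic carbon). The surroundings of the change are not the same word for word: in compound 3 it sits next to the ring sulfur, while in compound 2 it sits next to the ring nitrogen and next to the ring oxygen.

Because the earlier instance of the change gave a 1.4-fold higher number from compound 2 to compound 1 (0.15 log units; within the scatter), the step that the limit leaves unreadable from compound 3 to compound 4 is expected to be small as well. Since compound 3 sits at the limit of > 64 ug/mL in this assay, at which 1 of the 3 values shown sits, compound 4 is expected to land near that same limit in this assay, with estimated value 70 ug/mL, spanning 30 ug/mL to 150 ug/mL, and a substantial chance that only a limit is reported again.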

Compound 4, half-maximal inhibitory concentration: > 64 ug/mL
Compound 4 ended at the assay's limit; the forecaster's own chance of this, stated with the estimate: 60%; the middle value lies beyond the limit too.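

In this assay, compound 3 and compound 4 each give only a limit and not a number, so the step between them cannot be read: the limit of > 64 ug/mL in this assay, at which 2 of the 4 values shown sit.

The compounds shown leave open how far cyclohexylamino in place of benzyl(methyl)amino changes the result on the core of compound 3, and whether it stays as small there as a 1.4-fold higher number from compound 2 to compound 1 (0.15 log units; within the scatter).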